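The source may report more compounds than this note shows. Statements on the series, on what has been measured and on what is new or still open speak of the compounds shown alone.

Working notes on the series. For the measured compounds named here, the three measured members share one core, a diaryl ether linking a urea to a pyrimidine. Compound 1 `CNc1cc(Oc2c(F)cc(NC(=O)Nc3cccc(C(F)(F)F)c3)cc2F)ncn1` carries methylamino on the pyrimidine and two fluorines on the central ring; in an assay on isolated protein for inhibition of serine/threonine-protein kinase TNNI3K (Homo sapiens) (on this read-out higher numbers stand for weaker inhibition and lower numbers for stronger inhibition), compound 1 gives 20 nM. Compound 2 `CNc1cc(Oc2ccc(NC(=O)Nc3cccc(C(F)F)c3)cc2)ncn1` keeps methylamino, drops the ring fluorines and replaces trifluoromethyl with difluoromethyl; in this assay compound 2 gives 100 nM. Compound 3 `Nc1cc(Oc2ccc(NC(=O)Nc3cccc(C(F)(F)F)c3)cc2)ncn1` has an unsubstituted amino group on the pyrimidine and no ring fluorines; in this assay compound 3 gives 25 nM.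

Among the three numbers compound 3 stands second highest. Its nearest neighbour is compound 1, whose number is lower by a margin within the scatter, so no order between them can be read. Compound 2 lies furthest away, with a higher number beyond the scatter. Compounds 1 and 3 differ in more than one place, so no single change can be credited for their similar numbers.

Compound 4 `CCNc1cc(Oc2ccc(NC(=O)Nc3cccc(C(F)(F)F)c3)cc2)ncn1` is not yet measured. It differs from compound 3 by ethyl in place of hydrogen on a nitrogen on an aromatic ring. Going by the values given here, no step between measured compounds isolates this change. In this assay compound 3 and compound 1 show that a small alkyl on that nitrogen, together with other changes, sits within the scatter of the unsubstituted amine, so for compound 4 no step beyond the scatter is expected in either direction. The expected step from compound 3 to compound 4 is a 1.2-fold higher number from compound 3 to compound 4 (0.08 log units; within the scatter). Compound 4 is therefore estimated at 30 nM, with a range of 12 nM to 80 nM.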

Compound 4, half-maximal inhibitory concentration: 25 nM
The estimate for compound 4 lay 1.2-fold (0.08 log units) above the measured number; the range from low to high includes it.
By their numbers in this assay, from the lowest: compounds 1, 3 and 4 (each within the scatter of the next); then compound 2.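

Ethyl in place of hydrogen on a nitrogen on an aromatic ring gives no change at the digits printed from compound 3 to compound 4 (within the scatter) in this assay, and this is the first step in the series that isolates a change at this position, with the rest of the structure held constant. Earlier, the amino and methylamino compounds differed in more than one place, so their similar numbers could not be credited to the nitrogen substituent alone; here, amino to ethylamino on the trifluoromethyl urea without ring fluorines leaves the number within the scatter, so this position accepts ethyl without a readable loss or gain in this assay. Nothing shown speaks to why the number holds when ethyl enters, and no supporting measurement bears on the result.

The compounds shown leave open how far this holds, since a longer chain such as n-butyl, a ring such as cyclopropyl, or a chain ending in a hydroxyl or a basic amine on this nitrogen could behave differently from ethyl. Also open, as far as these compounds go, is whether ethylamino gives the same result when combined with the ring fluorines of compound 1 or with the difluoromethyl group of compound 2.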